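The compounds below may be only part of what the source reports. "The series", "measured", "known", "first", "only" and "open" are said of these compounds alone.

Working notes on the series. Compound 3 `NC(=O)c1cccc(NC(=O)c2cc(Cl)ccc2O)c1` sits at a limit in an ADME assay on cells (Macrophage, Mus musculus) for cytotoxicity, read by resazurin assay, with a stated time of 3 days; on this read-out lower numbers stand for stronger inhibition and higher numbers for weaker inhibition: compound 3 gives > 60000 nM, a limit of the assay and not a number. The same holds for compound 1 `O=C(O)c1cccc(NC(=O)c2cc(Cl)ccc2O)c1`, which in this assay gives > 60000 nM, again only a limit. Going by the values given here, compound 2 `CCOC(=O)c1cccc(NC(=O)c2cc(Cl)ccc2O)c1` is the one member with a number, giving 17000 nM in this assay. Within the three, an at least 3.5-fold lower number from compound 1 to compound 2 (0.54 log units; beyond the scatter) and an at least 3.5-fold higher number from compound 2 to compound 3 (0.54 log units; beyond the scatter), while a step that the two limits leave unreadable from compound 1 to compound 3; the limits cap what can be read, since (the limit of > 60000 nM in this assay, at which 2 of the 3 values shown sit).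

Compound 4 `O=C(Nc1ccccc1)c1cccc(NC(=O)c2cc(Cl)ccc2O)c1` differs from compound 3 by phenyl in place of hydrogen on an amide-type nitrogen, and to be measured in this assay. The measured step that bears on it is the change on the other side of the carbonyl, where ethyl in place of hydrogen gave an at least 3.5-fold lower number from compound 1 to compound 2 (0.54 log units; beyond the scatter), and its reverse, amino in place of ethoxy, gave an at least 3.5-fold higher number from compound 2 to compound 3 (0.54 log units; beyond the scatter). Phenyl in place of hydrogen on the amide-type nitrogen is taken as a move of the same kind as the ethyl step, so a lower number of modest size is expected for compound 4, at most the size seen from compound 1 to compound 2, and the estimated step is an at least 2.4-fold lower number from compound 3 to compound 4 (0.38 log units; beyond the scatter). Compound 4 is therefore expected at about 25000 nM, within a range from 8000 nM to 70000 nM, with a fair chance that only a limit is returned.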

Compound 4, half-maximal inhibitory concentration: > 60000 nM
Compound 4: no number, only a limit; the forecaster's own chance of this, stated with the estimate: 35%; middle value at least 2.4-fold (0.38 log units) from the limit.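

Anilino in place of ethoxy on the carbonyl carbon gives an at least 3.5-fold higher number from compound 2 to compound 4 (0.54 log units; beyond the scatter), so a phenyl on the amide-type nitrogen does not bring back a readable number in this assay. Hydroxy, amino and anilino on this carbonyl carbon now all end at the limit of the assay, and among the four compounds only the ethoxy of compound 2 gives a number, so adding one six-membered aromatic ring of carbon is not enough here to bring a value into the readable range. The steps to compound 4 from compound 1 and from compound 3 cannot be read, since both ends of each step are limits and not numbers: the limit of > 60000 nM in this assay, at which 3 of the 4 values shown sit.

Going by these compounds, how far compound 1, compound 3 and compound 4 lie from one another past that limit stays open, and with it whether phenyl in place of hydrogen changes anything at all on the amide-type nitrogen. Also open, on these data alone, is whether the number of compound 2 is particular to ethoxy or would also appear with a methyl ester, a longer chain on the ester oxygen, or an ethyl group in place of phenyl on the amide-type nitrogen.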